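Replacing an isoindolinone ether with a 2-methoxyphenyl ether

The source may hold more compounds than are shown below. What is called first, only, known or untested is meant among the compounds shown, and "the series" means these compounds.

Compound 1 `Cc1cc(OC[C@H](C)COc2ccc(C(=O)CC(C)(C)C)c(O)c2C)ccc1C(=O)O`: 305 nM
Compound 2 `Cc1c(OC[C@@H](C)COc2ccc3c(c2)C(=O)NC3)ccc(C(=O)CC(C)(C)C)c1O`: > 10000 nM

In an assay for positive allosteric modulation of metabotropic glutamate receptor 2 (Rattus norvegicus) (on this read-out lower numbers stand for an effect already at smaller amounts and higher numbers for an effect only at larger amounts of compound), compound 1 gives 305 nM. Compound 2 reaches only a limit, > 10000 nM, in this assay. Among the measured compounds shown here, the one measured step is an at least 32-fold higher number from compound 1 to compound 2 (1.51 log units; beyond the scatter), which sets compound 2 at the limit of > 10000 nM in this assay, at which 1 of the 2 values shown sits. Compound 3 `COc1ccccc1OC[C@H](C)COc1ccc(C(=O)CC(C)(C)C)c(O)c1C` differs from compound 2 by a group of 8 heavy atoms (7 carbon, 1 oxygen; one six-membered aromatic ring of carbon only) in place of a group of 10 heavy atoms (8 carbon, 1 nitrogen, 1 oxygen; one five-membered non-aromatic ring with 1 hetero atom, one six-membered aromatic ring of carbon only), on an oxygen on a saturated carbon. For the measured compounds named here, this undoes the group that accompanied the large loss from compound 1 to compound 2, but what enters is not the group of compound 1; the 2-methoxyphenyl group has no measured counterpart here, so only the direction is supported. Compound 3 is therefore expected to return toward a measurable number, with a step of an at least 5.0-fold lower number from compound 2 to compound 3 (0.69 log units; beyond the scatter) in this assay. The estimate for compound 3 in this assay is 2000 nM, ranging from 400 nM to 10000 nM.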

Compound 3, half-maximal effective concentration: "not active" (no number reported)
No number was reported for compound 3, so the estimate cannot be set against anything.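

Among the compounds shown here, compound 3 is reported as "not active" in this assay, without a number, so no step from compound 2 to compound 3 can be read. The compounds shown leave open whether any group other than that of compound 1, on the oxygen on a saturated carbon, gives a measurable number.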